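The source may hold more compounds than are shown below. What is called first, only, known or untested is meant among the compounds shown, and "the series" means these compounds.

Of the compounds shown here, two that share one core have been tested in an in vitro functional assay on cells for agonist activity at Bombesin receptor subtype-3 (Mus musculus), read by luminescence and calcium flux; a higher number here means that more compound is needed for the effect, a lower number that less compound is needed. Compound 1, `CCC(C)(C)Cc1c[nH]c(CCc2ccc(-c3ccccc3C(=O)O)cc2)n1`, carries a branched alkyl chain on its five-membered ring, and in this assay compound 1 gives 9.6 nM. Compound 2, `N#Cc1ccc(Cc2cnc(CCc3ccc(-c4ccccc4C(=O)O)cc3)[nH]2)cc1`, carries a 4-cyanobenzyl group in that position, and in this assay compound 2 gives 723 nM. Of the two numbers, compound 2 has the higher one, and the gap to compound 1 is far beyond the ordinary scatter of repeated measurements, so compound 2 needs much more substance for the same effect.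

Compound 3, `CC(C)(C)c1cnc(CCc2ccc(-c3ccccc3C(=O)O)cc2)[nH]1`, has not been measured yet. It differs from compound 2 in one place: tert-butyl in place of 4-cyanobenzyl on an aromatic carbon. Since the branched alkyl group of compound 1 goes with 9.6 nM while the 4-cyanobenzyl group of compound 2 goes with 723 nM, a return to an alkyl group is expected to lower the number. The step of a 12-fold lower number from compound 2 to compound 3 (1.08 log units; beyond the scatter) is expected to be downward and beyond the scatter. Compound 3 is therefore estimated at about 60 nM, within a range from 12 nM to 300 nM.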

Compound 3, half-maximal effective concentration: 2750 nM
Compound 3: middle estimate off by 46-fold (1.66 log units), on the low side; the measured number lies above the stated range.
By their numbers in this assay, from the lowest: compound 1; then compound 2; then compound 3.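

Replacing 4-cyanobenzyl with tert-butyl on this aromatic carbon gives a 3.8-fold higher number from compound 2 to compound 3 (0.58 log units; beyond the scatter) in this assay, so swapping the aromatic ring for an alkyl group does not by itself lower the number. Being a branched alkyl group is clearly not enough at this position: compound 1 gives 9.6 nM, whereas compound 3, which also carries one, gives 2750 nM. What lies behind these differences cannot be told from the information at hand.

The compounds shown leave open which feature of the branched chain of compound 1 goes with its low number, and whether a neopentyl group or a straight hexyl chain would stand nearer to compound 1 or to compound 3. A plain benzyl group would show whether the nitrile of compound 2 matters at all.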